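A Furan Gives Way to a Pyrrole

The source may report more compounds than this note shows. Statements on the series, on what has been measured and on what is new or still open speak of the compounds shown alone.

Compound 2 `CCN(Cc1ccco1)C(=O)COc1ccc(C)cc1` carries a furan where compound 1 `CCN(Cc1cccs1)C(=O)COc1ccc(C)cc1` carries a thiophene. In an assay on HEK293 cells for agonist activity at transient receptor potential cation channel subfamily M member 8 (Homo sapiens), read by fluorescence and calcium flux, with a stated time of 15 min (a higher number here means that more compound is needed for the effect, a lower number that less compound is needed), compound 1 gives 8 nM, whereas compound 2 gives 489 nM, the higher of the two numbers recorded. Among the measured compounds shown here, the single measured step, a 61-fold higher number from compound 1 to compound 2 (1.79 log units; beyond the scatter), shows that the ring on the saturated chain carbon bound to the amide-type nitrogen is a sensitive spot. Compound 3 `CCN(Cc1cc[nH]c1)C(=O)COc1ccc(C)cc1` alters this ring again: 1H-pyrrol-3-yl in place of furan-2-yl on a saturated chain carbon bound to an amide-type nitrogen. For the measured compounds named here, no measured pair shows this exact exchange, so only the thiophene-to-furan step bears on it, and that step was large. A further change of the ring is therefore expected to move the number again, most likely upward, though with a wide margin of uncertainty. For compound 3 the estimated step is a 1.8-fold higher number from compound 2 to compound 3 (0.26 log units; within the scatter). Compound 3 is expected to give about 900 nM in this assay, within 150 nM to 6000 nM.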

Compound 3, half-maximal effective concentration: 21800 nM
Compound 3: the middle estimate sits 24-fold (1.38 log units) below what was measured, outside the stated range (above it).
By their numbers in this assay, from the lowest: compound 1; then compound 2; then compound 3.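

In this assay, 1H-pyrrol-3-yl in place of furan-2-yl on a saturated chain carbon bound to an amide-type nitrogen brings a 45-fold higher number from compound 2 to compound 3 (1.65 log units; beyond the scatter), so the position proves sensitive to a second ring exchange, and the thiophene-to-furan step was not an isolated case. Measured against the thiophene, the exchange gives a 2700-fold higher number from compound 1 to compound 3 (3.44 log units; beyond the scatter), and the three rings now rank thiophen-2-yl, furan-2-yl, 1H-pyrrol-3-yl from the lowest number to the highest. Nothing available here accounts for this order.

The last exchange alters the hetero atom, the point of attachment and the hydrogen-bond donor count together, and the compounds shown do not separate these changes. A thiophen-3-yl, 1H-pyrrol-2-yl or 1-methylpyrrol-3-yl ring at this position would be needed to tell them apart.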